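Pyrimidin-2-yl for 1,3-thiazol-2-yl on a sulfonamide nitrogen

The source may hold more compounds than are shown below. What is called first, only, known or untested is meant among the compounds shown, and "the series" means these compounds.

Half-life describes how long a compound lasts in the body, and it can be compared across related structures. In an ADME assay on the whole organism (Mus musculus, strain BALB/c) for metabolic stability, read by LC-MS, with a stated time of 24 h, at a dose of 1 mg/kg by the intravenous route (a higher number here means that the compound lasts longer, a lower number that the compound disappears faster), compound 1 `O=S(=O)(Nc1ncccn1)c1ccc2c(c1)OCC[C@@H]2c1ccc(C(F)(F)F)cc1-c1ccc(F)nc1` gives 3.2 h and compound 2 `Cn1nccc1-c1cc(C(F)(F)F)ccc1[C@H]1CCOc2cc(S(=O)(=O)Nc3nccs3)ccc21` gives 2 h as its half-life. Compound 2 therefore stands within the usual scatter of compound 1, and these two numbers cannot be told apart.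

Still unmeasured is compound 3 `Cn1nccc1-c1cc(C(F)(F)F)ccc1[C@H]1CCOc2cc(S(=O)(=O)Nc3ncccn3)ccc21` with pyrimidin-2-yl in place of 1,3-thiazol-2-yl on a sulfonamide nitrogen. Going by the values given here, no measured pair shows this change alone, so the only guide is the level of the two measured compounds. No step beyond the scatter is expected, in either direction. The estimated step of a 1.3-fold higher number from compound 2 to compound 3 (0.10 log units; within the scatter) stays within the scatter. The expected half-life of compound 3 is 2.5 h within a range of 1.3 h to 4.8 h (estimated).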

Compound 3, half-life: 4.2 h
Compound 3: the middle estimate sits 1.7-fold (0.23 log units) below what was measured; low and high end bracket the measured number.
By their numbers in this assay, from the lowest: compounds 2, 1 and 3 (each within the scatter of the next, the first and the last beyond it).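

Holding the rest of the molecule fixed, the group on the sulfonamide nitrogen makes a measurable difference in this assay (a 2.1-fold higher number from compound 2 to compound 3 (0.32 log units; beyond the scatter)), a modest step and the first single change here that goes beyond the scatter. The change on an aromatic carbon, from 6-fluoropyridin-3-yl to 1-methyl-1H-pyrazol-5-yl, gives a different picture (a 1.3-fold higher number from compound 1 to compound 3 (0.12 log units; within the scatter)), so these two groups cannot be told apart in this comparison. Nothing available here explains why the pyrimidin-2-yl compound lasts longer than its 1,3-thiazol-2-yl partner.

The compounds shown leave open whether pyrimidin-2-yl gives the same step when 6-fluoropyridin-3-yl sits on the aromatic carbon. They also leave open how a plain phenyl ring or a 1,3-oxazol-2-yl group on the sulfonamide nitrogen would compare.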